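A few compounds are considered here, and "the series" means these few. Any claim that something is new, unique, unknown or untested is made for them only; others in the source may bear on it.

Compound 1 `Cc1ccc(-n2ncc(=O)[nH]c2=O)cc1C(=O)NCC1(O)CCCCCC1` gives 700 nM in a functional assay on cells for antagonist activity at P2X purinoceptor 7 (Homo sapiens), read by ELISA; a lower number here means a stronger inhibitor, a higher number a weaker inhibitor. Compound 3 `CCn1c(=O)cnn(-c2ccc(Cl)c(C(=O)NCC3(O)CCCCCC3)c2)c1=O` gives 86 nM in this assay. Compound 2 `O=C(NCC1CCOCC1)c1cc(-n2ncc(=O)[nH]c2=O)ccc1Cl` gives > 5000 nM in this assay, and this is a limit of the assay, not a number.

Of the three, compound 2 is the one that sits at the limit of > 5000 nM in this assay, at which 1 of the 3 values shown sits. Compound 4 `CCCOCCNC(=O)c1cc(-n2ncc(=O)[nH]c2=O)ccc1Cl` has not yet been measured. It differs from compound 2 in one place: propoxymethyl in place of oxan-4-yl on a saturated chain carbon bound to an amide-type nitrogen. Going by the values given here, no pair of measured compounds shows this kind of change, so its size cannot be read from the data. The expected step is a step that the limit leaves unreadable from compound 2 to compound 4, meaning none beyond the usual scatter. Compound 4 is therefore estimated at 8000 nM, in a range from 3000 nM to 30000 nM, with a real chance that only a limit is reported again.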

Compound 4, half-maximal inhibitory concentration: > 5000 nM
Compound 4 gave a limit, no number (the forecaster's own chance of this, stated with the estimate: 70%); the middle value is on the limit's open side.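

Going by these compounds alone, compound 2 and compound 4 both give only a limit, not a number, so no step between them can be read: the limit of > 5000 nM in this assay, at which 2 of the 4 values shown sit.

The compounds shown leave open how strongly either one inhibits, and whether propoxymethyl in place of oxan-4-yl changes that at all.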